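The source may report more compounds than this note shows. Statements on the series, on what has been measured and on what is new or still open speak of the compounds shown alone.

Of the compounds shown here, three from one series have been tested in a functional assay on HT-29 cells (Homo sapiens) for antiproliferative activity, read by MTT assay, with a stated time of 72 h; on this read-out higher numbers stand for weaker inhibition and lower numbers for stronger inhibition. Compound 1, `CCN(CC)CCn1cnnc1-c1cc(Oc2ccc(NC(=O)Nc3cccc(C(F)(F)F)c3)cc2F)ccn1`, gives 630 nM in this assay. Compound 2, `CCN(CC)CCn1cnnc1-c1cc(Oc2ccc(NC(=O)Nc3ccccc3C(F)(F)F)cc2F)ccn1`, differs from compound 1 only in one place: 2-(trifluoromethyl)phenyl in place of 3-(trifluoromethyl)phenyl on an amide-type nitrogen. In this assay compound 2 gives 3410 nM, which is a 5.4-fold higher number from compound 1 to compound 2 (0.73 log units; beyond the scatter). Compound 3, `CN(C)CCCn1cnnc1-c1cc(Oc2ccc(NC(=O)Nc3cccc(C(F)(F)F)c3)cc2F)ccn1`, keeps the ring substitution of compound 1 but its chain is altered: (dimethylamino)methyl in place of diethylamino on a saturated chain carbon, two bonds along the chain from an aromatic nitrogen. In this assay compound 3 gives 980 nM, a change of a 1.6-fold higher number from compound 1 to compound 3 (0.19 log units; within the scatter), so compound 1 and compound 3 cannot be told apart on this read-out.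

Compound 4, `CN(C)CCCn1cnnc1-c1cc(Oc2ccc(NC(=O)Nc3ccccc3C(F)(F)F)cc2F)ccn1`, is not yet measured. It stands to compound 3 as compound 2 stands to compound 1: 2-(trifluoromethyl)phenyl in place of 3-(trifluoromethyl)phenyl on an amide-type nitrogen. The change sits on the same amide-type nitrogen in both pairs, so it is the same change, carried out on the core of compound 3 rather than that of compound 1.

Among the compounds with values here, the only guide to what this change does is the pair of compound 1 and compound 2, where the number rose by a 5.4-fold higher number from compound 1 to compound 2 (0.73 log units; beyond the scatter). Starting from compound 3, a step of about the same size is expected, a 5.4-fold higher number from compound 3 to compound 4 (0.73 log units; beyond the scatter), because the step of a 5.4-fold higher number from compound 1 to compound 2 (0.73 log units; beyond the scatter) is the single measured example and the two cores differ only in the chain described. Compound 4 is therefore estimated to give about 5300 nM in this assay, with a likely range from 2500 nM to 12000 nM. Whether the shorter chain changes the size of the step is not known from these data.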

Compound 4, half-maximal inhibitory concentration: 3130 nM
For compound 4 the middle estimate is 1.7-fold (0.23 log units) above the measured one, within the range that was stated.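

In this assay, putting 2-(trifluoromethyl)phenyl in place of 3-(trifluoromethyl)phenyl on the amide-type nitrogen again weakens inhibition on the core of compound 3, giving a 3.2-fold higher number from compound 3 to compound 4 (0.50 log units; beyond the scatter), and this step does not differ measurably from the one seen on the core of compound 1: the same change on two cores in this assay, a 5.4-fold higher number (0.73 log units; beyond the scatter) from compound 1 to compound 2 and a 3.2-fold higher number (0.50 log units; beyond the scatter) from compound 3 to compound 4, 1.7-fold (0.23 log units) apart, within the scatter of two such steps. The chain change also carries over, since it makes no readable difference with 2-(trifluoromethyl)phenyl in place, giving a 1.1-fold lower number from compound 2 to compound 4 (0.04 log units; within the scatter), just as it made none with 3-(trifluoromethyl)phenyl: the same change on two cores in this assay, a 1.6-fold higher number (0.19 log units; within the scatter) from compound 1 to compound 3 and a 1.1-fold lower number (0.04 log units; within the scatter) from compound 2 to compound 4, 1.7-fold (0.23 log units) apart, within the scatter of two such steps. Together the two pairs show that, for these four compounds, the effect of the ring change can be carried from one core to the other and the chain change leaves it intact, but two pairs cannot establish a general rule, the gap in size between the two ring steps cannot be read as real, and nothing here explains why the ring change weakens inhibition.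

Going by these compounds, it remains open whether the same step would appear with a longer chain or with a morpholine at the end of the chain. On these data alone, it is also open how the result would change if a chlorine atom or a nitrile took the place of the trifluoromethyl group.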